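From 3-methylphenyl to 2-methylphenyl in a cytotoxicity series

The compounds below may be only part of what the source reports. "The series", "measured", "known", "first", "only" and "open" are said of these compounds alone.

Compound 1 `COc1ccc(Nc2nc(-c3cccc(F)c3)nc3ccc(F)cc23)cc1`: 32300 nM
Compound 2 `Fc1cccc(-c2nc(Nc3ccc(Br)cc3)c3cc(F)ccc3n2)c1`: > 50000 nM (a limit)
Compound 3 `Cc1cccc(Nc2nc(-c3cccc(F)c3)nc3ccc(F)cc23)c1`: > 50000 nM (a limit)

The three compounds were tested in a functional assay on U2OS cells (Homo sapiens) for cytotoxicity, read by MTT assay, with a stated time of 48 h; on this read-out higher numbers stand for weaker inhibition and lower numbers for stronger inhibition. Compound 3 gives > 50000 nM, which is a limit and not a number. It stands at the limit of > 50000 nM in this assay, at which 2 of the 3 values shown sit. Compound 2 gives > 50000 nM, also a limit. Compound 1 alone carries a number, 32300 nM.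

Compound 4 `Cc1ccccc1Nc1nc(-c2cccc(F)c2)nc2ccc(F)cc12` has the same atoms as compound 3, joined differently: 2-methylphenyl in place of 3-methylphenyl on a nitrogen on an aromatic ring. In words, this is 2-methylphenyl in place of 3-methylphenyl on a nitrogen on an aromatic ring.

For the measured compounds named here, no measured step makes this exact change. The nearest ones alter the same group on that nitrogen. They are an at least 1.5-fold higher number from compound 1 to compound 3 (0.18 log units; that floor lies within the scatter) and a step that the two limits leave unreadable from compound 2 to compound 3. A further step, an at least 1.5-fold higher number from compound 1 to compound 2 (0.18 log units; that floor lies within the scatter), concerns the same group. None of them shows a change beyond the scatter, so no step beyond the scatter is expected in this assay, and no direction can be given. The expected step is a number no higher from compound 3 to compound 4 (the limit leaves the size open). For compound 4 the estimated value is 50000 nM, with an expected range from 25000 nM to 90000 nM.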

Compound 4, half-maximal inhibitory concentration: > 50000 nM
Compound 4: a limit, no number; the forecaster's own chance of this, stated with the estimate: 70%; the middle value sits exactly at the limit.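

Compound 4 also ends at a limit in this assay, so 2-methylphenyl on this nitrogen gives no number, as 3-methylphenyl and 4-bromophenyl did before it, and the limit now holds most of the series: the limit of > 50000 nM in this assay, at which 3 of the 4 values shown sit.

The steps that join compound 4 to compound 3 and to compound 2 cannot be read, with a limit at both ends of each. The one step that can be read is an at least 1.5-fold higher number from compound 1 to compound 4 (0.18 log units; that floor lies within the scatter), so compound 4 is not shown to differ from compound 1 beyond the scatter.

On these data alone, whether moving the methyl between these two places on the phenyl ring changes anything in this assay stays open, with no number for compound 3 or compound 4 to compare. Also open, as far as these compounds go, is how the series would read with an amine or a carboxylic acid on the phenyl ring carried by this nitrogen.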